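Removing a Propyl Group: From Compound 2 to Compound 4

This account rests on a few compounds, and the source may have more. Where it says the series, first, only, none or still open, it means among the compounds named here.

Measured compounds:
compound 1 `CCCCCCOP(=O)(O)OCCSC(=S)N1CCCCCC1`: 17200 nM
compound 2 `CCCCCCOP(=O)(O)OCCSC(=S)N1CCN(C)CC1`: 73000 nM
compound 3 `CCCOP(=O)(O)OCCSC(=S)N1CCCCCC1`: 38000 nM

All three were tested in a functional assay on MDA-MB-231 cells (Homo sapiens) for inhibition, read by MTT assay, with stated times of 18 h and 4 h; on this read-out lower numbers stand for stronger inhibition and higher numbers for weaker inhibition. Compound 2 carries 4-methylpiperazin-1-yl in place of azepan-1-yl on a thiocarbonyl carbon, and that change made a step of a 4.2-fold higher number from compound 1 to compound 2 (0.63 log units; beyond the scatter). Compound 3 carries hydrogen in place of propyl on a saturated chain carbon, three bonds along the chain from an oxygen on an unsaturated carbon, a step of a 2.2-fold higher number from compound 1 to compound 3 (0.34 log units; beyond the scatter). Compound 4 `CCCOP(=O)(O)OCCSC(=S)N1CCN(C)CC1` has not been measured; it differs from compound 2 by hydrogen in place of propyl on a saturated chain carbon, three bonds along the chain from an oxygen on an unsaturated carbon. The place of this change is the same, word for word, as the place of the change from compound 1 to compound 3, so it is the same change made on the core of compound 2 instead of the core of compound 1. Within the data shown here, compound 4 is therefore expected to show a step of a 2.2-fold higher number from compound 2 to compound 4 (0.34 log units; beyond the scatter) in this assay, about as large as the earlier one, because the step of a 2.2-fold higher number from compound 1 to compound 3 (0.34 log units; beyond the scatter) is the only guide available. Compound 4 is estimated at 160000 nM, between 70000 nM and 360000 nM.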

Compound 4, half-maximal inhibitory concentration: 62000 nM
For compound 4 the middle estimate is 2.6-fold (0.41 log units) above the measured one; the whole stated range lies above it.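

Shortening hexyl to propyl gave a 1.2-fold lower number from compound 2 to compound 4 (0.07 log units; within the scatter) in this assay and so left the number within the usual scatter on the core of compound 2. Set beside the same change on the core of compound 1, this step cannot be told apart from the earlier one: the same change on two cores in this assay, a 2.2-fold higher number (0.34 log units; beyond the scatter) from compound 1 to compound 3 and a 1.2-fold lower number (0.07 log units; within the scatter) from compound 2 to compound 4, 2.6-fold (0.42 log units) apart, within the scatter of two such steps. The change may therefore carry over from one core to the other, but this is not proven: one pair on each core cannot separate a real difference from scatter, and two cores say nothing about the rest of the series.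

The compounds shown leave open what a longer chain such as octyl, or a chain ending in an amine, would do on either core.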